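Swapping Trifluoromethyl for Fluoro in a Small Cytotoxic Set

The source may report more compounds than this note shows. Statements on the series, on what has been measured and on what is new or still open speak of the compounds shown alone.

Among the measured compounds shown here, in a functional assay on HepG2 cells (Homo sapiens) for cytotoxicity, read by spectrophotometry, with a stated time of 72 h (a lower number here means a stronger inhibitor, a higher number a weaker inhibitor), three compounds with a shared core have numbers so far. Compound 1 `COc1cc(-c2cccc(=O)n2-c2ccc([N+](=O)[O-])cc2)cc(OC)c1OC` gives 941 nM with its 4-nitrophenyl group, and compound 2 `COc1cc(-c2cccc(=O)n2-c2ccncc2)cc(OC)c1OC` gives 2520 nM with pyridin-4-yl instead. Compound 3 `COc1cc(-c2cccc(=O)n2-c2ccc(C(F)(F)F)cc2)cc(OC)c1OC` gives 10200 nM as the highest number of the three. Compound 4 `COc1cc(-c2cccc(=O)n2-c2ccc(F)cc2)cc(OC)c1OC` is still unmeasured and carries fluoro in place of trifluoromethyl on an aromatic carbon, para to a large group, a swap counted as fluoro in place of trifluoromethyl on an aromatic carbon in full.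

For the measured compounds named here, two measured steps bear on this. Trifluoromethyl replacing nitro gave an 11-fold higher number from compound 1 to compound 3 (1.04 log units; beyond the scatter) and that step is large, while pyridin-4-yl replacing 4-nitrophenyl gave a 2.7-fold higher number from compound 1 to compound 2 (0.43 log units; beyond the scatter) and that step is modest. Neither step involves fluoro, so the guide is indirect. With compound 3 at 10200 nM on top of the three, a lower number is expected. The expected change is a 2.6-fold lower number from compound 3 to compound 4 (0.41 log units; beyond the scatter) as a moderate step. Compound 4 is estimated at 4000 nM with 1300 nM to 12000 nM as the expected range.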

Compound 4, half-maximal inhibitory concentration: > 100000 nM
Compound 4 ended at the assay's limit (the forecaster's own chance of this, stated with the estimate: 3%); at least 25-fold (1.39 log units) between middle value and limit.
By their numbers in this assay, from the lowest: compound 1; then compound 2; then compound 3. At a limit, above all of these: compound 4.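

The entry for compound 4 in this assay is a limit of the assay, not a number: the limit of > 100000 nM in this assay, at which 1 of the 4 values shown sits. Even so, the change at this position, on an aromatic carbon para to a large group, can be read: replacing trifluoromethyl with the single fluorine atom gives an at least 9.8-fold higher number from compound 3 to compound 4 (0.99 log units; beyond the scatter), so the shorter group did not restore activity. Among the compounds shown here, the other two comparisons, an at least 39-fold higher number from compound 2 to compound 4 (1.59 log units; beyond the scatter) and an at least 100-fold higher number from compound 1 to compound 4 (2.02 log units; beyond the scatter), show that this part of the molecule can do more than shift the value within a measurable range, as the earlier compounds did, and can take it all the way to the limit.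

What the compounds shown leave open is what a chloro group, an amine or a carboxylic acid would give at this same place. They also leave open whether the nitro group of compound 1 stands alone in giving the lowest number.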